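The compounds below may be only part of what the source reports. "The series", "measured", "known", "first", "only" and "open" are said of these compounds alone.

Compound 1 `CC1CN(c2cccnc2)C(=O)c2ccc(Cl)cc21` is one of two compounds tested in an ADME assay on cells for inhibition of cytochrome P450 11B1, mitochondrial (Homo sapiens), read by HTRF; on this read-out lower numbers stand for stronger inhibition and higher numbers for weaker inhibition. In this assay compound 1 gives 2590 nM, the higher of the two numbers; compound 2 `CCC(=O)N[C@@H]1CCCc2c1cncc2N1C(=O)c2ccc(Cl)cc2[C@@H]1C` gives 414 nM in this assay, a gap beyond the usual scatter. The step to compound 3 `CC1(C)CN(c2cccnc2)C(=O)c2ccc(Cl)cc21` is a single change: methyl in place of hydrogen on a saturated ring carbon. Within the data shown here, no step of this kind has been measured here; the step expected, a 1.2-fold lower number from compound 1 to compound 3 (0.07 log units; within the scatter), is small, not beyond the scatter in either direction. On that basis compound 3 is estimated at 2200 nM in this assay, in the range 800 nM to 6500 nM.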

Compound 3, half-maximal inhibitory concentration: > 10000 nM
Compound 3: no number, only a limit; the forecaster's own chance of this, stated with the estimate: 5%; middle value at least 4.5-fold (0.65 log units) away from the limit.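

In this assay, this saturated ring carbon proves sensitive to a very small change: one methyl in place of hydrogen gives an at least 3.8-fold higher number from compound 1 to compound 3 (0.58 log units; beyond the scatter). This shows that the addition of a single carbon here can weaken inhibition beyond the scatter. Compound 3 gives only a limit of the assay, not a number: the limit of > 10000 nM in this assay, at which 1 of the 3 values shown sits.

Going by these compounds, the full size of the step therefore stays open. Also open, on these data alone, is how an ethyl chain, a hydroxyl or an amine would read on this carbon, and whether the same methyl would matter on the core of compound 2.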